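Swapping methoxy for chloro on a styryl sulfone

The source may report more compounds than this note shows. Statements on the series, on what has been measured and on what is new or still open speak of the compounds shown alone.

Compound 1, with the structure `COc1ccc(/C=C/S(=O)(=O)Cc2ccc(OC)cc2)cc1`, was tested in a functional assay on DU-145 cells (Homo sapiens) for antiproliferative activity, read by trypan blue exclusion; on this read-out higher numbers stand for weaker inhibition and lower numbers for stronger inhibition. In this assay compound 1 gives > 20000 nM, which is a limit of the assay rather than a measured number. Compound 1 therefore sits at the limit of > 20000 nM in this assay, at which 1 of the 2 values shown sits, so its true position is known only as somewhere beyond that boundary. A second measured compound, compound 2 with the structure `COc1cc(OC)c(/C=C/S(=O)(=O)Cc2ccc(C(=O)O)cc2)c(OC)c1`, carries a different set of substituents on both rings; in this assay compound 2 gives 10000 nM.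

The compound still to be measured is compound 3, with the structure `COc1ccc(CS(=O)(=O)/C=C/c2ccc(Cl)cc2)cc1`. It differs from compound 1 in one place: chloro in place of methoxy on an aromatic carbon. Among the measured compounds shown here, no measured pair in this set shows what this particular exchange does, so the size and direction of the step can only be guessed. The expected step from compound 1 to compound 3 is an at least 2.0-fold lower number from compound 1 to compound 3 (0.30 log units; that floor lies within the scatter), leaning towards somewhat stronger inhibition, but with a real chance that the assay again reports only a limit. The estimated value for compound 3 in this assay is 10000 nM, within a range from 2000 nM to 40000 nM.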

Compound 3, half-maximal inhibitory concentration: 2500 nM
Compound 3: middle estimate off by 4.0-fold (0.60 log units), on the high side; measured number inside the range.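

At this place, on an aromatic carbon para to a large group, chloro in place of methoxy gives an at least 8.0-fold lower number from compound 1 to compound 3 (0.90 log units; beyond the scatter) in this assay. Among the compounds shown here, this is the first comparison in the set between two compounds that differ in one place only, and it shows that the group at this position matters for the read-out: compound 3 gives a measured number, 2500 nM, and not a limit. The true size of the step stays unknown, and the printed size is only a floor, because compound 1 is reported only as a limit of the assay: the limit of > 20000 nM in this assay, at which 1 of the 3 values shown sits.

With chloro as the only replacement for methoxy at this place, the compounds shown leave open whether chloro itself matters or whether removing methoxy is enough, and fluoro, a methyl group or a nitrile at the same carbon would help to separate those two readings. They also leave open whether the same exchange would have a similar effect on the other ring, which keeps its methoxy in compound 3.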